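This account rests on a few compounds, and the source may have more. Where it says the series, first, only, none or still open, it means among the compounds named here.

Measured so far:
compound 1 `Cc1cc(C(=O)c2ccccc2)ccc1OCC(=O)Nc1nc(-c2ccccc2)cs1` – 22300 nM
compound 2 `COc1ccc(-c2csc(NC(=O)COc3ccc(C(=O)c4ccccc4)cc3C)n2)cc1` – 25700 nM

In a functional assay on DLA cells (Mus musculus) for cytotoxicity, read by MTT assay, with a stated time of 48 h (on this read-out higher numbers stand for weaker inhibition and lower numbers for stronger inhibition), compound 1 gives 22300 nM, the lowest of the two numbers, with compound 2 at 25700 nM as its nearest neighbour. Among the compounds with values here, the only measured step, a 1.2-fold higher number from compound 1 to compound 2 (0.06 log units; within the scatter), concerns a different change and lies within the scatter, so nothing indicates that a small aromatic substituent moves the numbers here. Compound 3 `Cc1cc(C(=O)c2ccccc2)cc(C)c1OCC(=O)Nc1nc(-c2ccccc2)cs1` differs from compound 1 by methyl in place of hydrogen on an aromatic carbon. Within the data shown here, no step of this kind has been measured; the one step available gives no reason to expect movement beyond the scatter, so an expected 1.0-fold lower number from compound 1 to compound 3 (0.01 log units; within the scatter) is taken as essentially flat. Compound 3 is therefore estimated at 22000 nM, with a range of 11000 nM to 45000 nM.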

Compound 3, half-maximal inhibitory concentration: 19400 nM
Compound 3: middle estimate off by 1.1-fold (0.05 log units), on the high side; the measured number falls inside the stated range.
By their numbers in this assay, from the lowest: compounds 3, 1 and 2 (each within the scatter of the next).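

In this assay, methyl in place of hydrogen on this aromatic carbon, ortho to a large group and meta to a benzoyl group, gives a 1.1-fold lower number from compound 1 to compound 3 (0.06 log units; within the scatter) and so leaves the number unchanged within the scatter. Within the data shown here, compounds 1 and 2 differed by methoxy at another place, so this is the first reading for this position and for this change. No measurement bearing on the reason for this flat step is available.

Going by these compounds, whether an amine, a carboxylic acid or a longer chain at this carbon would move the number remains open. A single methyl step also cannot show whether the same change would behave alike on other members of the series.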